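The source may hold more compounds than are shown below. What is called first, only, known or untested is meant among the compounds shown, and "the series" means these compounds.

Three compounds have been measured in an ADME assay on L02 cells (Homo sapiens) for cytotoxicity, read by MTT assay, with a stated time of 72 h; a lower number here means a stronger inhibitor, a higher number a weaker inhibitor:

Compound 1 `Cc1ccccc1NC(=O)CCC(=O)OCCCCCCSc1ccc([N+](=O)[O-])c2nonc12` gives 9490 nM.
Compound 2 `O=C(CCC(=O)OCCCCCCSc1ccc([N+](=O)[O-])c2nonc12)Nc1ccc(Br)cc1` gives 4330 nM.
Compound 3 `COc1ccc(NC(=O)CCC(=O)OCCCCCCSc2ccc([N+](=O)[O-])c3nonc23)cc1OC` gives 4100 nM.

Compound 2 stands second highest of the three numbers. Its nearest neighbour is compound 3, since a 1.1-fold lower number from compound 2 to compound 3 (0.02 log units; within the scatter) lies within the scatter; its furthest is compound 1, since a 2.2-fold lower number from compound 1 to compound 2 (0.34 log units; beyond the scatter) lies beyond it. Compound 4 `O=C(CCC(=O)N1CCCCC1)OCCCCCCSc1ccc([N+](=O)[O-])c2nonc12` differs from compound 2 in one place: piperidin-1-yl in place of (4-bromophenyl)amino on a carbonyl carbon. Going by the values given here, no measured step touches the amide nitrogen itself: a 2.3-fold lower number from compound 1 to compound 3 (0.36 log units; beyond the scatter) and the other two steps only exchange one aryl group on that nitrogen for another, and both exchanges out of compound 1 were modest. With nothing directly comparable, no step beyond the scatter is expected, and a 1.2-fold higher number from compound 2 to compound 4 (0.06 log units; within the scatter) is the expected change. Compound 4 is therefore estimated at 5000 nM, in the range 2000 nM to 13000 nM.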

Compound 4, half-maximal inhibitory concentration: 3970 nM
Compound 4: the middle estimate sits 1.3-fold (0.10 log units) above what was measured; low and high end bracket the measured number.
By their numbers in this assay, from the lowest: compounds 4, 3 and 2 (each within the scatter of the next); then compound 1.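

In this assay, piperidin-1-yl on this carbonyl carbon gives a number that cannot be told apart from those of two aryl amino compounds: a 1.1-fold lower number from compound 2 to compound 4 (0.04 log units; within the scatter) and a 1.0-fold lower number from compound 3 to compound 4 (0.01 log units; within the scatter) both lie within the scatter, while a 2.4-fold lower number from compound 1 to compound 4 (0.38 log units; beyond the scatter) lies beyond it and is modest. Among these compounds, therefore, neither the aromatic ring nor the amide hydrogen is needed for a number at this level, and compound 1 alone stands apart. Nothing measured here explains these numbers.

On these data alone, whether a carboxylic acid on this carbonyl carbon, or a morpholin-4-yl or open-chain dialkylamino group in place of piperidin-1-yl, would move the number remains open.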